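Cyclohexylamino series: phenyl substituent and tolerated concentration

The compounds below may be only part of what the source reports. "The series", "measured", "known", "first", "only" and "open" are said of these compounds alone.

Compound 1 `c1cnc2nc(-c3ccc(OC4CCCC4)cc3)c(NC3CCCCC3)n2c1` gives 39000 nM in a toxicity assay on A549 cells (Homo sapiens) for cytotoxicity, read by luminescence and CellTiter-Glo, with a stated time of 48 h; a higher number here means that more compound is tolerated, a lower number that less compound is tolerated. Compound 2 `Clc1ccc(-c2nc3ncccn3c2NC2CCCCC2)cc1` gives only a limit there, > 100000 nM. Going by the values given here, compound 2 therefore stands at the limit of > 100000 nM in this assay, at which 1 of the 2 values shown sits, and the single measured step, an at least 2.5-fold higher number from compound 1 to compound 2 (0.40 log units; beyond the scatter), ends at that limit, so its full size is unknown. Compound 3 `Oc1ccccc1-c1nc2ncccn2c1NC1CCCCC1` differs from compound 2 by 2-hydroxyphenyl in place of 4-chlorophenyl on an aromatic carbon. Among the compounds with values here, no measured step covers a hydroxyl group. Compound 3 is expected to show a step of a number no higher from compound 2 to compound 3 (the limit leaves the size open), likely within the scatter. Compound 3 is estimated at 100000 nM, with a range from 40000 nM to 250000 nM, and a limit is again likely.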

Compound 3, half-maximal cytotoxic concentration: > 100000 nM
Compound 3: only a limit was reported; the forecaster's own chance of this, stated with the estimate: 60%; the middle value lies on the limit itself.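

Compound 2 and compound 3 both give only a limit, so no step between them can be read: the limit of > 100000 nM in this assay, at which 2 of the 3 values shown sit.

The compounds shown leave open whether 2-hydroxyphenyl and 4-chlorophenyl differ at all in this assay.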